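Moving the Pyridine Nitrogen: What Solubility to Expect

The source may hold more compounds than are shown below. What is called first, only, known or untested is meant among the compounds shown, and "the series" means these compounds.

Compounds measured so far:
Compound 1, `COC(=O)c1cccc(-c2cnc3[nH]cc(-c4cccnc4)c3c2)c1`, in a physicochemical assay for solubility, read by HPLC, using the shake flask method (on this read-out higher numbers stand for higher solubility and lower numbers for lower solubility), gives 1900 nM.
Compound 2, `N#Cc1cccc(-c2cnc3[nH]cc(-c4cccnc4)c3c2)c1`, in this assay gives 7200 nM.

Compound 1 stands lowest of the two numbers. Among the compounds with values here, its only neighbour is compound 2, reached by a 3.8-fold higher number from compound 1 to compound 2 (0.58 log units; beyond the scatter), a change described as cyano in place of methoxycarbonyl on an aromatic carbon.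

Compound 3, `COC(=O)c1cccc(-c2cnc3[nH]cc(-c4ccncc4)c3c2)c1`, has not yet been measured. It differs from compound 1 by pyridin-4-yl in place of pyridin-3-yl on an aromatic carbon. The two compounds are built from the same atoms, joined differently. Within the data shown here, no measured step touches this part of the molecule: the one step available, a 3.8-fold higher number from compound 1 to compound 2 (0.58 log units; beyond the scatter), concerns a different group on a different ring and so offers no direct guide. With nothing in the measured pairs pointing either way, no step beyond the scatter is expected, so the step of a 1.1-fold higher number from compound 1 to compound 3 (0.02 log units; within the scatter) is expected to be small. Compound 3 is therefore estimated at 2000 nM, with a likely range from 900 nM to 4500 nM.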

Compound 3, solubility: 30900 nM
Estimate against measurement, compound 3: 15-fold (1.19 log units) below; measured number outside the range, above it.
By their numbers in this assay, from the lowest: compound 1; then compound 2; then compound 3.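

Moving the ring nitrogen turns out to matter a great deal at this place in the molecule: in this assay, putting pyridin-4-yl in place of pyridin-3-yl on an aromatic carbon of the five-membered aromatic ring gives a 16-fold higher number from compound 1 to compound 3 (1.21 log units; beyond the scatter) and this large step is the first sign of that, since the earlier pair concerned only a different group on a different ring. The group that leaves and the group that enters have the same heavy atoms, the same counts of hydrogen-bond donors and acceptors and no net charge, so these simple counts do not separate compound 1 from compound 3. No measurement at hand explains why the two differ so much.

On these data alone, whether the same change would give a step of similar size with the nitrile of compound 2 in place of the methoxycarbonyl group remains open. Also open, as far as these compounds go, is what pyridin-2-yl, a plain phenyl ring or an aminopyridine would give at this same place, so two pyridine isomers cannot yet show a trend across this position.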